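The compounds below may be only part of what the source reports. "The series", "measured", "known", "first", "only" and "open" are said of these compounds alone.

Of the compounds shown here, three built on one shared core have been tested in a functional assay on DU-145 cells (Homo sapiens) for cytotoxicity, read by MTT assay; a lower number here means a stronger inhibitor, a higher number a weaker inhibitor. Compound 1 `CC(C)=CC[C@@H](OC[C@H](C)O)C1=CC(=O)c2c(O)ccc(O)c2C1=O` gives 24500 nM. Compound 2 `CC[C@](C)(O)CC(=O)O[C@H](CC=C(C)C)C1=CC(=O)c2c(O)ccc(O)c2C1=O`, in which the side chain on the oxygen on a saturated carbon is an ester, gives 20500 nM. Compound 3 `CC(C)=CC[C@@H](OC(=O)CC(C)(O)C(C)C)C1=CC(=O)c2c(O)ccc(O)c2C1=O` gives 16900 nM. Compound 3 therefore sits at the low end of the three numbers, but only by small margins: a 1.4-fold lower number from compound 1 to compound 3 (0.16 log units; within the scatter), and a 1.2-fold lower number from compound 2 to compound 3 (0.08 log units; within the scatter). The first two compounds are also close to each other, since a 1.2-fold lower number from compound 1 to compound 2 (0.08 log units; within the scatter).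

Compound 4 `CC(C)=CC[C@@H](OC(=O)C1CCCOC1)C1=CC(=O)c2c(O)ccc(O)c2C1=O` has not yet been measured. It keeps the ester but changes what hangs on the carbonyl carbon: oxan-3-yl in place of 2-hydroxy-2,3-dimethylbutyl on a carbonyl carbon. The group that leaves has one hydrogen-bond donor and no ring; the group that enters has one six-membered non-aromatic ring with one hetero atom and no hydrogen-bond donor.

All three measured steps alter this same side chain, and none of them moved the number beyond the scatter. The expected step for compound 4 is accordingly of similar size, a 1.0-fold higher number from compound 3 to compound 4 (0.00 log units; within the scatter), in no firm direction. Compound 4 is estimated to give 17000 nM, with a likely range from 7000 nM to 40000 nM.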

Compound 4, half-maximal inhibitory concentration: 29700 nM
Compound 4: middle estimate off by 1.7-fold (0.24 log units), on the low side, within the range that was stated.
By their numbers in this assay, from the lowest: compounds 3, 2, 1 and 4 (each within the scatter of the next).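

In this assay the step of a 1.8-fold higher number from compound 3 to compound 4 (0.24 log units; within the scatter) replaces the open chain, which carries a hydrogen-bond donor, with oxan-3-yl, a six-membered non-aromatic ring with no hydrogen-bond donor, and the step of a 1.4-fold higher number from compound 2 to compound 4 (0.16 log units; within the scatter) makes the same kind of swap from the shorter chain. Compound 4 is the first of these compounds with a ring in this side chain and the first with no hydrogen-bond donor there, yet the step of a 1.2-fold higher number from compound 1 to compound 4 (0.08 log units; within the scatter) shows that even the comparison with the 2-hydroxypropyl side chain stays close, so among these four compounds neither feature separates one number from another. No measurement is available that could explain why the numbers stay so close.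

From the compounds shown here alone, all four values lie within the scatter of their neighbours, so it remains open whether any side chain at this oxygen can shift the number clearly in either direction. An amine or a carboxylic acid on the carbonyl carbon, or a much longer carbon chain there, would probe this position over a wider range than these compounds do.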